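Thioether swap on compound 1: working notes

The source may hold more compounds than are shown below. What is called first, only, known or untested is meant among the compounds shown, and "the series" means these compounds.

Within the data shown here, in a functional assay on A549 cells (Homo sapiens) for inhibition, read by CCK-8 assay, with a stated time of 72 h, tested at 8 uM (a higher number here means more inhibition of growth at the concentration tested, a lower number less inhibition of growth), compound 1 (`Cc1cc(C)cc(SCc2ccc(/C=C/C(=O)Nc3ccccc3N)cc2)c1`) gives 47.3% and is the lower of the two numbers so far. Compound 2 (`COc1ccc(SCc2ccc(C(=O)Nc3ccccc3N)cc2)cc1`) gives 70.7% and lies higher by more than the scatter. Compound 3 (`Nc1ccccc1NC(=O)/C=C/c1ccc(CSCCc2ccccc2)cc1`) has phenethyl in place of 3,5-dimethylphenyl on a sulfur. Among the measured compounds shown here, no measured pair shows this change, so no step beyond the scatter is expected in this assay for now. The estimated step (a number 2.7 percentage points higher from compound 1 to compound 3 (within the scatter)) is small and upward, with wide uncertainty. The expected value for compound 3 is 50% (estimated range 30% to 70%).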

Compound 3, percent growth inhibition at one concentration: 50.3%
Beside the measured number, compound 3's estimate is 0.3 percentage points below it, and the stated range covers the measured number.
By their numbers in this assay, from the lowest: compounds 1 and 3 (each within the scatter of the next); then compound 2.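

Among these compounds, at the sulfur, phenethyl in place of 3,5-dimethylphenyl gives a number 3 percentage points higher from compound 1 to compound 3 (within the scatter) in this assay, the first reading of a change at this position. The two groups share a heavy-atom count and one six-membered aromatic ring of carbon only, and this read-out does not separate them. No available measurement explains this result.

Compound 2 differs from compound 1 in more than one place, so no single change accounts for its number. On these data alone, whether a longer chain or a terminal amine on the sulfur would give a step beyond the scatter remains open.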